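The source may report more compounds than this note shows. Statements on the series, on what has been measured and on what is new or still open speak of the compounds shown alone.

Working notes on the series. Among the compounds with values here, in a functional assay on the whole organism with Mus musculus as the target (a lower number here means a smaller maximal response, a higher number a larger maximal response), compound 2, `CN(C)CCCn1c(=O)n(C2OC(CO)[C@@H](O)[C@H]2O)c2nc(N)nc(O)c21`, gives the largest of the three numbers measured so far, 63%. Compound 3, `C=CCSc1nc2c(O)nc(N)nc2n1C1OC(CO)[C@@H](O)[C@H]1O`, gives 57% in this assay, which lies within the scatter of compound 2. Compound 1, `C=CCn1c(=O)n([C@H]2CO[C@@H](CO)C2)c2nc(N)nc(O)c21`, gives 16% in this assay, a number well beyond the scatter below compound 2. Within the data shown here, no two measured compounds differ in one place only, so no single-change step is known in this assay.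

Compound 4, `Nc1nc(O)c2c(n1)n(C1OC(CO)[C@@H](O)[C@H]1O)c(=O)n2Cc1ccc([N+](=O)[O-])cc1`, is not yet measured. It differs from compound 2 by 4-nitrophenyl in place of 2-(dimethylamino)ethyl on a saturated chain carbon bound to an aromatic nitrogen. Among the measured compounds shown here, no measured pair carries this change, so its effect is unknown. A moderate decrease in this assay is expected, estimated as a number 18 percentage points lower from compound 2 to compound 4 (beyond the scatter). Compound 4 is expected to give 45%, within a range of 15% to 75%.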

Compound 4, largest response reached (reported as maximal response), in percent of the reference or control that the assay uses: 16%
For compound 4 the middle estimate is 29 percentage points above the measured one; measured number inside the range.
By their numbers in this assay, from the lowest: compounds 1 and 4 (each within the scatter of the next); then compounds 3 and 2 (each within the scatter of the next).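

Within the data shown here, this is the first single-change reading at this place, on a saturated chain carbon bound to an aromatic nitrogen: in this assay, 4-nitrophenyl in place of 2-(dimethylamino)ethyl gives a number 47 percentage points lower from compound 2 to compound 4 (beyond the scatter) on the shared core. The maximal response therefore depends on the group carried here, at least for this pair. Nothing available bears on the cause of this step.

As far as these compounds go, whether the step follows the entering 4-nitrophenyl or the leaving dimethylamino group remains open. A plain benzyl, or a morpholine at the end of the propyl chain, would separate the two.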